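Indole-substituted pyran series: single-ring replacements for naphthalen-1-yl

The source may hold more compounds than are shown below. What is called first, only, known or untested is meant among the compounds shown, and "the series" means these compounds.

Measured so far:
compound 1 `N#CC1=C(N)OC(c2c[nH]c3ccccc23)=C(C#N)C1c1cccc2ccccc12` — 7.7%
compound 2 `N#CC1=C(N)OC(c2c[nH]c3ccccc23)=C(C#N)C1c1ccccc1` — 24.5%
compound 3 `N#CC1=C(N)OC(c2c[nH]c3ccccc23)=C(C#N)C1c1ccc(Br)cc1` — 10.6%

In a functional assay, tested at 200 ug/mL (on this read-out higher numbers stand for a stronger effect at the one concentration tested and lower numbers for a weaker effect), compound 1 gives 7.7%, the lowest of the three numbers. Its nearest neighbour is compound 3, and the step of a number 2.9 percentage points higher from compound 1 to compound 3 (within the scatter) lies within the scatter. Going by the values given here, the step of a number 16.8 percentage points higher from compound 1 to compound 2 (beyond the scatter) is the only one from compound 1 that goes beyond the scatter. Within the single-ring pair, a number 13.9 percentage points lower from compound 2 to compound 3 (beyond the scatter) is likewise a modest step.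

Compound 4 `Cc1ccccc1C1C(C#N)=C(N)OC(c2c[nH]c3ccccc23)=C1C#N` has not yet been measured. The change from compound 1 is 2-methylphenyl in place of naphthalen-1-yl on a saturated ring carbon. Both steps from compound 1 that bear on this change, a number 16.8 percentage points higher from compound 1 to compound 2 (beyond the scatter) and a number 2.9 percentage points higher from compound 1 to compound 3 (within the scatter), replace the naphthalen-1-yl with a single six-membered aromatic ring; one gives a modest rise, the other stays within the scatter. A rise of modest size is therefore expected, as a number 7.3 percentage points higher from compound 1 to compound 4 (within the scatter), though a step within the scatter cannot be ruled out given compound 3. On this basis compound 4 is estimated at 15% in this assay, with a range from 5% to 28%.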

Compound 4, a percentage reported as activity, at one concentration (the size of the read-out at that concentration, not a potency): 21.4%
The estimate for compound 4 lay 6.4 percentage points below the measured number; measured number inside the range.
By their numbers in this assay, from the lowest: compounds 1 and 3 (each within the scatter of the next); then compounds 4 and 2 (each within the scatter of the next).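

In this assay, 2-methylphenyl on this saturated ring carbon stands apart from naphthalen-1-yl, with a number 13.7 percentage points higher from compound 1 to compound 4 (beyond the scatter), and from 4-bromophenyl, with a number 10.8 percentage points higher from compound 3 to compound 4 (beyond the scatter), so a substituted single ring need not stay at the low end of the series. Adding a methyl to the phenyl gives a number 3.1 percentage points lower from compound 2 to compound 4 (within the scatter), whereas adding a bromo gave a number 13.9 percentage points lower from compound 2 to compound 3 (beyond the scatter), so not every addition to the phenyl lowers the number. Nothing available explains these differences.

As far as these compounds go, it remains open whether the gap between the two substituted phenyls belongs to the group or to where it sits, as methyl appears only in 2-methylphenyl and bromo only in 4-bromophenyl. Also open, from the compounds shown here alone, is how a phenyl bearing a hydroxy, methoxy or dimethylamino group, or a cyclohexyl group in the same place, would read.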